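This account rests on a few compounds, and the source may have more. Where it says the series, first, only, none or still open, it means among the compounds named here.

In an ADME assay on BJ cells (Homo sapiens) for cytotoxicity, with a stated time of 72 h (a higher number here means that more compound is needed for the effect, a lower number that less compound is needed), compound 1 (`COCCOc1cc2ncnc(-n3nc(-c4ccccn4)nc3N)c2cc1OCCOC`) gives > 27000 nM, which is a limit of the assay. Compound 2 (`COCCOc1cc2c(-n3nc(-c4ccccn4)nc3N)ncnc2cc1OC`) gives > 13000 nM, which is also a limit, so it has no exact number. Compound 3 (`CCOC(=O)NCCCOc1cc2c(-n3nc(-c4ccccn4)nc3N)ncnc2cc1OC`) carries 3-((ethoxycarbonyl)amino)propoxy in place of 2-methoxyethoxy: ((ethoxycarbonyl)amino)methyl in place of methoxy on a saturated chain carbon, two bonds along the chain from an oxygen on an aromatic ring. Among the measured compounds shown here, the only measured step bearing on this change is a step that the two limits leave unreadable from compound 1 to compound 2. Because a step that the two limits leave unreadable from compound 1 to compound 2 offers no size to carry over, no step beyond the scatter is expected in this assay. The estimated step is a step that the limit leaves unreadable from compound 2 to compound 3. Compound 3 is expected to give 20000 nM, within an estimated range of 8000 nM to 45000 nM.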

Compound 3, half-maximal effective concentration: > 11000 nM
Compound 3 was reported as a limit; the forecaster's own chance of this, stated with the estimate: 70%; the middle value does not contradict the limit.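

Compound 1, compound 2 and compound 3 are all reported only as limits in this assay, so no step can be read among them. The compounds shown leave open whether 3-((ethoxycarbonyl)amino)propoxy in place of 2-methoxyethoxy changes the read-out at all.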